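A Relocated Methyl Group and Compound 4

The source may hold more compounds than are shown below. What is called first, only, known or untested is meant among the compounds shown, and "the series" means these compounds.

Compound 3 `CCn1ncc2c(F)cc(-c3ccc(C(CC)(CC)c4nnc(C)[nH]4)c(=O)[nH]3)cc21` is the starting point. In an ADME assay on microsomes from liver (Homo sapiens) for metabolic stability (a lower number here means that the compound disappears faster, a higher number that the compound lasts longer), compound 3 gives > 3 h as its reading, which is a limit and not a number. Compound 1 `CC(C)C(Nc1nnc[nH]1)c1ccc(-c2ccc3cccc(F)c3c2)[nH]c1=O` gives > 3 h as its reading, and this too is a limit. Compound 2 `CCn1ncc2c(F)cc(-c3ccc(C(CC)(CC)c4nnc[nH]4)c(=O)[nH]3)cc21` gives 2.7 h as a measured number. Read together, the series shows the limit of > 3 h in this assay, at which 2 of the 3 values shown sit, and so leaves compound 3 without an exact place.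

Compound 4 `CCn1ncc2c(F)cc(-c3ccc(C(CC)(CC)c4nncn4C)c(=O)[nH]3)cc21` has the same atoms as compound 3, joined differently. The change is 4-methyl-4H-1,2,4-triazol-3-yl in place of 5-methyl-4H-1,2,4-triazol-3-yl on a saturated chain carbon bound to an aromatic carbon and two saturated chain carbons with 4-methyl-4H-1,2,4-triazol-3-yl in place of 5-methyl-4H-1,2,4-triazol-3-yl on a saturated chain carbon bound to an aromatic carbon and two saturated chain carbons.

Going by the values given here, only one measured step bears on this, methyl in place of hydrogen on an aromatic carbon, which gave an at least 1.1-fold higher number from compound 2 to compound 3 (0.04 log units; that floor lies within the scatter) in this assay and serves as the sole guide. No measured compound carries the 4-methyl-4H-1,2,4-triazol-3-yl group, so the size of this change is not shown directly. On that basis no step beyond the scatter is expected, and no direction is favoured. The estimated step is a number no higher from compound 3 to compound 4 (the limit leaves the size open) at its middle. For compound 4 the estimated value is 3 h with an expected range from 1.5 h to 6 h in this measurement.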

Compound 4, half-life: 2.67 h
Beside the measured number, compound 4's estimate is 1.1-fold (0.05 log units) above it; measured number inside the range.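

Compound 4 gives the methylated group an exact reading. Moving the methyl to form the 4-methyl-4H-1,2,4-triazol-3-yl group gives, in this assay, an at least 1.1-fold lower number from compound 3 to compound 4 (0.05 log units; that floor lies within the scatter). Methyl in place of hydrogen on an aromatic nitrogen gives a 1.0-fold lower number from compound 2 to compound 4 (0.00 log units; within the scatter), and since both ends of this step are exact numbers, it shows that a methyl at this place on the group brings no step beyond the scatter. The step that starts at compound 3 can be read only as a floor because the reading of compound 3 is a limit and not a number: the limit of > 3 h in this assay, at which 2 of the 4 values shown sit.

On these data alone, how far compound 3 lies past its limit stays open, and with it the true size of the relocation of the methyl. Also open, as far as these compounds go, is how this assay would respond to a longer chain such as ethyl on the same aromatic nitrogen, or to an amine on the aromatic carbon of the 4-methyl-4H-1,2,4-triazol-3-yl group.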